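Hydroxy to methoxy on compound 3

This account rests on a few compounds, and the source may have more. Where it says the series, first, only, none or still open, it means among the compounds named here.

Values so far in a functional assay on the whole organism with Mus musculus as the target (a lower number here means that less compound is needed, a higher number that more compound is needed for the effect), for three compounds
- compound 1 `CN1CCCC(O)(c2ccccc2)C1=O` gives 128 mg/kg
- compound 2 `COC1(c2ccccc2)CCCNC1=O` gives 49.6 mg/kg
- compound 3 `CCOC(=O)N1CCCC(O)(c2ccccc2)C1=O` gives 124 mg/kg

Compound 3 sits level with compound 1 within the scatter, and compound 2 has a lower number than either, beyond the scatter. Next in view is compound 4 `CCOC(=O)N1CCCC(OC)(c2ccccc2)C1=O`, made from compound 3 by the change (methyl in place of hydrogen on an oxygen on a saturated carbon), which reads hydroxy to methoxy.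

For the measured compounds named here, only one measured step exists in this set, a 1.0-fold lower number from compound 1 to compound 3 (0.01 log units; within the scatter), and it concerns ethoxycarbonyl in place of methyl on an amide-type nitrogen in a ring. It says that this swap shows nothing beyond the scatter in the hydroxy pair, but it does not touch the oxygen. Going by the values given here, no step for methylating the hydroxy alone has been measured. Among the compounds with values here, the nearest hint is compound 2, the only methoxy compound so far, at 49.6 mg/kg in this assay. That compound also carries the amide hydrogen, so its gap cannot be assigned to the methoxy alone.

A modest move to a lower number is therefore expected, and the expected step is a 1.7-fold lower number from compound 3 to compound 4 (0.22 log units; within the scatter) overall. For compound 4 the estimate is 75 mg/kg, with an expected range of 35 mg/kg to 160 mg/kg in all.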

Compound 4, dose for half-maximal effect: 124 mg/kg
The estimate for compound 4 lay 1.7-fold (0.22 log units) below the measured number, within the range that was stated.
By their numbers in this assay, from the lowest: compound 2; then compounds 3, 4 and 1 (each within the scatter of the next).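

On the ethoxycarbonyl-bearing core in this assay, methyl in place of hydrogen on the oxygen gives no change at the digits printed from compound 3 to compound 4 (within the scatter), so this position tolerates the hydroxy to methoxy change without a readable shift, at least with this nitrogen substituent. For the compounds shown here, the new compound also supplies the first single-change comparison at the amide-type nitrogen within the methoxy pair: ethoxycarbonyl in place of hydrogen gives a 2.5-fold higher number from compound 2 to compound 4 (0.40 log units; beyond the scatter), a step beyond the scatter, whereas ethoxycarbonyl in place of methyl in the hydroxy pair gives a 1.0-fold lower number from compound 1 to compound 3 (0.01 log units; within the scatter), within it. In this set, the nitrogen substituent therefore accounts for the only readable single-change difference, though these two steps start from different groups on nitrogen, and nothing available bears on the reason for this.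

As far as these compounds go, whether the oxygen stays as undemanding when the ring nitrogen carries the amide hydrogen remains open, since that comparison would need the hydroxy partner of compound 2. Also open, from the compounds shown here alone, is whether a longer chain on the oxygen, such as propyl, or an amine-bearing chain there would read level with methyl.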